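This account rests on a few compounds, and the source may have more. Where it says the series, first, only, none or still open, it means among the compounds named here.

Compound 1, `CCOc1ccc(Cc2nnc(CN(c3cccc(Cl)c3C)S(=O)(=O)c3ccc(C)cc3)o2)cc1`, stands with the lowest of the three numbers recorded in an assay on CHO cells for displacement of a labelled ligand from prostaglandin E2 receptor EP1 subtype (Homo sapiens) (a lower number here means a stronger inhibitor, a higher number a weaker inhibitor), where compound 1 gives 3.98 nM. Its nearest neighbour is compound 2, `CCOc1ccc(Cc2nnc(CN(c3cccc(Cl)c3Cl)S(=O)(=O)c3ccc(C)cc3)o2)cc1`, which in this assay gives 6.31 nM; the step of a 1.6-fold higher number from compound 1 to compound 2 (0.20 log units; within the scatter) lies within the scatter. Further off is compound 3, `COc1ccc(Nc2nnc(CN(c3cccc(Cl)c3Cl)S(=O)(=O)c3ccc(C)cc3)o2)cc1`, which gives 39.8 nM, and the step of a 6.3-fold higher number from compound 2 to compound 3 (0.80 log units; beyond the scatter) is the one clear change among the measured compounds.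

The unmeasured compound 4, `COc1ccc(NCc2nnc(CN(c3cccc(Cl)c3C)S(=O)(=O)c3ccc(C)cc3)o2)cc1`, differs from compound 1 as follows: (4-methoxyphenyl)amino in place of 4-ethoxyphenyl on a saturated chain carbon bound to an aromatic carbon. Read one bond further out, this is 4-ethoxybenzyl giving way to ((4-methoxyphenyl)amino)methyl, so the saturated chain carbon is kept and only the aryl part is exchanged for an arylamino part.

Among the measured compounds shown here, the step that bears on this is the one from compound 2 to compound 3, where the 4-ethoxybenzyl was replaced by (4-methoxyphenyl)amino and the number rose by a 6.3-fold higher number from compound 2 to compound 3 (0.80 log units; beyond the scatter). Since compound 4 keeps the intervening chain carbon, a somewhat smaller rise is expected, and the step from compound 1 to compound 4 is estimated as a 3.0-fold higher number from compound 1 to compound 4 (0.48 log units; beyond the scatter). Compound 4 is therefore expected to give about 12 nM, in a range from 4 nM to 40 nM.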

Compound 4, half-maximal inhibitory concentration: 20 nM
Compound 4: middle estimate off by 1.7-fold (0.22 log units), on the low side; the measured number falls inside the stated range.
By their numbers in this assay, from the lowest: compounds 1 and 2 (each within the scatter of the next); then compounds 4 and 3 (each within the scatter of the next).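

With the saturated chain carbon kept, exchanging 4-ethoxybenzyl for ((4-methoxyphenyl)amino)methyl still weakens inhibition in this assay, with a 5.0-fold higher number from compound 1 to compound 4 (0.70 log units; beyond the scatter). The entering group has the same number of heavy atoms and the same aromatic ring as the group it replaces, yet it adds a hydrogen-bond donor and an acceptor, and the step stands beyond the scatter, in the same direction as a 6.3-fold higher number from compound 2 to compound 3 (0.80 log units; beyond the scatter); among the compounds shown, both exchanges that bring in a (4-methoxyphenyl)amino group at this place raise the number, and no compound goes against this, although two pairs are a narrow basis. The data shown offer nothing that accounts for the rise at this position.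

This exchange alters the nitrogen and the ether together, so the compounds shown leave open how much of the rise goes with the amine nitrogen and how much with methoxy standing in place of ethoxy, a question that a (4-ethoxyphenyl)amino group on the same chain carbon would separate. Also open, going by these compounds, is how the number would respond to an N-methyl amine or an amide carbonyl at this place.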